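The source may report more compounds than this note shows. Statements on the series, on what has been measured and on what is new or still open speak of the compounds shown alone.

Four compounds sharing one core are compared here in a physicochemical assay for solubility, with a stated time of 18 h, at pH 7.4; on this read-out higher numbers stand for higher solubility and lower numbers for lower solubility. Compound 2 `COc1ccc(F)cc1CNCCCNc1ccnc2cc(Oc3ccc(F)cc3)ccc12` gives 14500 nM, and compound 1 `COc1ccc(F)cc1CNCCCNc1ccnc2cc(Cc3ccc(C#N)cc3)ccc12` gives 4200 nM. Compound 3 `COc1cccc(CNCCCNc2ccnc3cc(Oc4ccc(F)cc4)ccc23)c1O` gives 14500 nM. Compound 3 differs from compound 2 by 2-hydroxy-3-methoxyphenyl in place of 5-fluoro-2-methoxyphenyl on a saturated chain carbon bound to an amine nitrogen, and no change at the digits printed from compound 2 to compound 3 (within the scatter). Compound 1 differs from compound 2 by 4-cyanobenzyl in place of 4-fluorophenoxy on an aromatic carbon, and a 3.5-fold lower number from compound 2 to compound 1 (0.54 log units; beyond the scatter). Compound 4 `COc1cccc(CNCCCNc2ccnc3cc(Cc4ccc(C#N)cc4)ccc23)c1O` has not been measured in this assay; it differs from compound 3 by 4-cyanobenzyl in place of 4-fluorophenoxy on an aromatic carbon, the same change as that from compound 2 to compound 1, made twice among these compounds. Because compound 3 stands at 14500 nM and a 3.5-fold lower number from compound 2 to compound 1 (0.54 log units; beyond the scatter), a step of similar size is expected, namely a 3.5-fold lower number from compound 3 to compound 4 (0.54 log units; beyond the scatter). Compound 4 is therefore estimated at 4200 nM, between 1500 nM and 12000 nM.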

Compound 4, solubility: 4200 nM
Compound 4: middle estimate and measured number agree at the digits printed; measured number inside the range.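

In this assay, 4-cyanobenzyl in place of 4-fluorophenoxy gives a 3.5-fold lower number from compound 3 to compound 4 (0.54 log units; beyond the scatter), the same size as a 3.5-fold lower number from compound 2 to compound 1 (0.54 log units; beyond the scatter), while the change of the other aryl group gives no change at the digits printed from compound 1 to compound 4 (within the scatter). This shows that the step carried over intact between these two closely related pairs, but one repeat cannot show that it would hold on other cores in the series. Nothing given here explains why the number drops with this change. As far as these compounds go, it remains open whether an amine or a carboxylic acid in place of 4-cyanobenzyl would behave the same way on both cores. From the compounds shown here alone, a longer chain in place of the saturated chain is equally open.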